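The compounds below may be only part of what the source reports. "The series", "measured", "known", "first", "only" and "open" are said of these compounds alone.

Among the measured compounds shown here, compound 1, `CCCCCCCCCCCCCCNC(=O)[C@H](CO)NCc1ccccc1O`, is one of two compounds measured in a functional assay on cells (Homo sapiens) for cytotoxicity, read by MTT assay, with a stated time of 24 h (a higher number here means a weaker inhibitor, a lower number a stronger inhibitor), where compound 1 gives 75300 nM. Its companion, compound 2, `CCCCCCCCCCCCCCNC(=O)[C@H](CO)/N=C/c1ccccc1O`, differs only in the group attached to the saturated chain carbon bound to a carbonyl carbon and a saturated chain carbon, and compound 2 gives 19000 nM. That single exchange produced a 4.0-fold lower number from compound 1 to compound 2 (0.60 log units; beyond the scatter).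

Compound 3, `CCCCCCCCCCCCCCNC(=O)[C@H](CO)/N=C/c1ccccc1C`, has not yet been measured. It differs from compound 1 as follows: a group of 9 heavy atoms (8 carbon, 1 nitrogen; one six-membered aromatic ring of carbon only) in place of a group of 9 heavy atoms (7 carbon, 1 nitrogen, 1 oxygen; one six-membered aromatic ring of carbon only), on a saturated chain carbon bound to a carbonyl carbon and a saturated chain carbon. For the measured compounds named here, the step from compound 1 to compound 2 bears on part of this change, since compound 2 likewise carries a double bond outside aromatic rings in place of the (2-hydroxybenzyl)amino group; the loss of the hydroxyl, however, has no measured counterpart here. Compound 3 is therefore expected to show a lower number than compound 1, estimated as a 2.5-fold lower number from compound 1 to compound 3 (0.40 log units; beyond the scatter), though smaller than the step to compound 2. The estimate for compound 3 is 30000 nM, expected to fall between 9000 nM and 100000 nM.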

Compound 3, half-maximal inhibitory concentration: 87700 nM
Beside the measured number, compound 3's estimate is 2.9-fold (0.47 log units) below it; measured number inside the range.
By their numbers in this assay, from the lowest: compound 2; then compounds 1 and 3 (each within the scatter of the next).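

In this assay, methyl in place of hydroxy on an aromatic carbon, with the double bond outside aromatic rings kept, gives a 4.6-fold higher number from compound 2 to compound 3 (0.66 log units; beyond the scatter), so the lower number of compound 2 does not carry over once the hydroxy group is gone. Against the (2-hydroxybenzyl)amino group of compound 1, the full exchange gives a 1.2-fold higher number from compound 1 to compound 3 (0.07 log units; within the scatter), so at this place on the saturated chain carbon the double bond without the hydroxy group brings no separation from compound 1. No evidence at hand speaks to the reason for these numbers.

Still open, on these data alone, is whether the lower number depends on hydroxy itself or would also appear with an amino or methoxy group on that aromatic carbon. Also open, as far as these compounds go, is whether the same holds with a shorter chain on the shared core.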